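Adding a second core hydroxy to the catechol coumarin

The source may hold more compounds than are shown below. What is called first, only, known or untested is meant among the compounds shown, and "the series" means these compounds.

Working notes on a small coumarin set in an assay on CHO cells for displacement of a labelled ligand from adenosine receptor A1 (Homo sapiens), read by radioligand binding; a higher number here means a weaker inhibitor, a lower number a stronger inhibitor. Compound 1 `COc1cccc2cc(-c3ccc([N+](=O)[O-])cc3)c(=O)oc12` reaches only the assay limit, > 100000 nM, a limit and not a number (the limit of > 100000 nM in this assay, at which 1 of the 3 values shown sits). Compound 2 `O=c1oc2c(O)c(O)ccc2cc1-c1ccc(O)cc1` gives 12500 nM. Compound 3 `O=c1oc2c(O)cccc2cc1-c1ccc(O)c(O)c1` gives 6200 nM, and its gap to compound 2 lies within the usual scatter, so the two numbers cannot be told apart. Compound 4 `O=c1oc2c(O)c(O)ccc2cc1-c1ccc(O)c(O)c1` differs from compound 3 by hydroxy in place of hydrogen on an aromatic carbon, joining the core hydroxylation of compound 2 with the ring substitution of compound 3. For the measured compounds named here, no measured pair tells what such a step does here, so no step beyond the scatter is expected in this assay, in either direction. Compound 4 is estimated at 5000 nM, between 1500 nM and 20000 nM, the expected step being a 1.2-fold lower number from compound 3 to compound 4 (0.09 log units; within the scatter).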

Compound 4, inhibition constant: 6280 nM
Estimate against measurement, compound 4: 1.3-fold (0.10 log units) below; measured number inside the range.
By their numbers in this assay, from the lowest: compounds 3, 4 and 2 (each within the scatter of the next). At a limit, above all of these: compound 1.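

In this assay, hydroxy in place of hydrogen on an aromatic carbon, ortho to a hydroxy group on the fused system of two rings, gives a 1.0-fold higher number from compound 3 to compound 4 (0.01 log units; within the scatter) as its first readable step at this position. The same exchange on another aromatic carbon gives a 2.0-fold lower number from compound 2 to compound 4 (0.30 log units; within the scatter) and so neither step lies beyond the scatter, even with both hydroxy patterns joined in compound 4. Nothing shown bears on why these steps stay within the scatter.

As far as these compounds go, an amine or a carboxylic acid in place of this hydroxy remains open, as does whether any such group would give a step beyond the scatter.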